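The compounds below may be only part of what the source reports. "The series", "measured", "known", "first", "only" and "open" are said of these compounds alone.

Working notes on the series. All three measured compounds share one core and differ only in the group on an aromatic carbon of its five-membered ring: compound 1 `CCCCc1nc2cccc(C(=O)O)c2n1Cc1ccc(-c2ccccc2-c2noc(O)n2)cc1` carries butyl, compound 2 `CCCOc1nc2cccc(C(=O)O)c2n1Cc1ccc(-c2ccccc2-c2noc(O)n2)cc1` propoxy, compound 3 `CSc1nc2cccc(C(=O)O)c2n1Cc1ccc(-c2ccccc2-c2noc(O)n2)cc1` methylsulfanyl. In a functional assay on the whole organism for inhibition, with Rattus norvegicus as the target, with a stated time of 3 h, at a dose of 1 mg/kg by the oral route (a lower number here means less inhibition, a higher number more inhibition at the dose given (going by the name of the read-out)), compound 1 gives 68%, compound 2 gives 100% and compound 3 gives 100%. Compound 3 therefore stands level with compound 2 at the digits reported, the two together being the highest of the three numbers, and the gap to compound 1 is large, a number 32 percentage points higher from compound 1 to compound 3 (beyond the scatter).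

Compound 4 `CCNc1nc2cccc(C(=O)O)c2n1Cc1ccc(-c2ccccc2-c2noc(O)n2)cc1` is the next step from compound 3: ethylamino in place of methylsulfanyl on an aromatic carbon. Within the data shown here, two measured steps bear on it. Replacing propoxy by methylsulfanyl gave no change at the digits printed from compound 2 to compound 3 (within the scatter), so exchanging one heteroatom-linked group for another left the read-out where it was, whereas replacing the all-carbon butyl gave a number 32 percentage points higher from compound 1 to compound 3 (beyond the scatter). Among the measured compounds shown here, no measured compound carries an amino group at this carbon, so the ethylamino case rests on analogy alone. The expectation is a step of no size beyond the scatter, a number 5 percentage points lower from compound 3 to compound 4 (within the scatter), with only downward room since compound 3 already sits at the top of the read-out. Compound 4 is estimated at 95%, within 75% to 100%.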

Compound 4, a percentage reported as inhibition, in the whole organism at one dose (the size of the read-out at that dose, not a potency): 25%
Beside the measured number, compound 4's estimate is 70 percentage points above it, outside the stated range (below it).
By their numbers in this assay, from the lowest: compound 4; then compound 1; then compounds 2 and 3 (each within the scatter of the next).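

In this assay, the position does not treat all heteroatom-linked groups alike: ethylamino in place of methylsulfanyl gives a number 75 percentage points lower from compound 3 to compound 4 (beyond the scatter), and ethylamino in place of propoxy gives a number 75 percentage points lower from compound 2 to compound 4 (beyond the scatter), so the match between compound 2 and compound 3 does not extend to this group. Ethylamino in place of the all-carbon butyl also gives a number 43 percentage points lower from compound 1 to compound 4 (beyond the scatter), which means that among these four compounds a heteroatom link at this carbon does not by itself give a higher number than butyl, with compound 4 the one that goes against that reading. No measurement at hand bears on what lies behind this drop.

Ethylamino differs from methylsulfanyl in carrying 1 hydrogen-bond donor rather than 0, and the compounds shown cannot separate that difference from the change of linking atom or chain, a question that dimethylamino, which keeps the nitrogen link and has no amine hydrogen, or ethylsulfanyl, which keeps the two-carbon chain on sulfur, would address. As far as these compounds go, it also remains open whether the drop is specific to the ethyl chain or is shared by a plain amine or by methylamino.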